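A few compounds are considered here, and "the series" means these few. Any claim that something is new, unique, unknown or untested is made for them only; others in the source may bear on it.

Of the compounds shown here, three sharing one core have been measured in an assay on U2OS cells for inhibition of secreted frizzled-related protein 1 (Homo sapiens), read by a luciferase reporter, with a stated time of 18 h; on this read-out higher numbers stand for an effect only at larger amounts of compound and lower numbers for an effect already at smaller amounts. Compound 1 `CN(C)c1ccc(C(=O)N2CCC(NS(=O)(=O)c3cc(S(=O)(=O)c4ccccc4)ccc3C(F)(F)F)CC2)cn1` gives 70 nM in this assay. Compound 2 `O=C(O)c1ccc(N2CCC(NS(=O)(=O)c3cc(S(=O)(=O)c4ccccc4)ccc3C(F)(F)F)CC2)cc1` gives 230 nM, and compound 3 `CC(C)(C)OC(=O)N1CCC[C@H]1C(=O)N1CCC(NS(=O)(=O)c2cc(S(=O)(=O)c3ccccc3)ccc2C(F)(F)F)CC1` gives 60 nM. Compound 3 thus holds the lowest of the three numbers; its gap to compound 1 lies within the scatter, while its gap to compound 2 lies beyond it. The two single-place steps measured so far are a 3.3-fold higher number from compound 1 to compound 2 (0.52 log units; beyond the scatter) and a 1.2-fold lower number from compound 1 to compound 3 (0.07 log units; within the scatter).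

Compound 4 `O=C(C1CCNCC1)N1CCC(NS(=O)(=O)c2cc(S(=O)(=O)c3ccccc3)ccc2C(F)(F)F)CC1` has not yet been measured. It differs from compound 3 in one place: piperidin-4-yl in place of 1-(tert-butoxycarbonyl)pyrrolidin-2-yl on a carbonyl carbon. This is the same carbonyl carbon that was altered in the step from compound 1 to compound 3, and that step stayed within the scatter, which suggests that exchanging the group on this carbon changes the numbers little. Within the data shown here, the only step that went beyond the scatter, from compound 1 to compound 2, replaced the whole carbonyl group and bears on compound 4 only loosely. Among the measured compounds shown here, no measured compound carries a hydrogen-bond donor at this position, so that feature has no direct guide in the data. Compound 4 is therefore expected to show a small step, a 1.7-fold higher number from compound 3 to compound 4 (0.22 log units; within the scatter), toward a somewhat higher number. The estimate for compound 4 is 100 nM, with a range from 30 nM to 400 nM.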

Compound 4, half-maximal effective concentration: 150 nM
Estimate against measurement, compound 4: 1.5-fold (0.18 log units) below; measured number inside the range.
By their numbers in this assay, from the lowest: compounds 3 and 1 (each within the scatter of the next); then compounds 4 and 2 (each within the scatter of the next).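

In this assay, the group on the carbonyl carbon now proves able to shift the number beyond the scatter, both in the step (a 2.5-fold higher number from compound 3 to compound 4 (0.40 log units; beyond the scatter)) and in the step (a 2.1-fold higher number from compound 1 to compound 4 (0.33 log units; beyond the scatter)), whereas the earlier exchange on this carbon (a 1.2-fold lower number from compound 1 to compound 3 (0.07 log units; within the scatter)) stayed within it. Piperidin-4-yl is also the first group on this carbon that counts a hydrogen-bond donor, and the change to it from compound 3 lowers the count of heavy atoms in the group and removes the defined stereocentre of the leaving group, so this single step mixes several differences. The replacement of the 4-carboxyphenyl group by (piperidin-4-yl)carbonyl on the ring nitrogen (a 1.5-fold lower number from compound 2 to compound 4 (0.19 log units; within the scatter)) stays within the scatter, and nothing available explains any of these shifts.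

From the compounds shown here alone, it remains open whether a plain pyrrolidin-2-yl, with the same ring as in compound 3 but without the tert-butoxycarbonyl group, would give a number closer to that of compound 3 or of compound 4. A piperidin-4-yl carrying a tert-butoxycarbonyl group would likewise separate the effect of that group from the effect of the ring.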